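The compounds below may be only part of what the source reports. "The series", "measured", "known", "first", "only" and "open" are said of these compounds alone.

Compound 1 `CC[C@H]1CN(c2nc(N)c(C(=O)NCC(C)(C)O)nc2Cl)CCN1C1CCN(Cc2ccc(Cl)cc2)CC1`: 8.4 nM
Compound 2 `CC[C@H]1CN(c2nc(N)c(C(=O)NCCNS(N)(=O)=O)nc2Cl)CCN1C1CCN(Cc2ccc(Cl)cc2)CC1`: 1.9 nM

Both values come from an in vitro assay on BaF3 cells for displacement of a labelled ligand from C-X-C chemokine receptor type 3 (Homo sapiens); on this read-out lower numbers stand for stronger inhibition and higher numbers for weaker inhibition. Within the data shown here, compound 2 gives the lowest of the two numbers in this assay, and the single measured step, a 4.4-fold lower number from compound 1 to compound 2 (0.65 log units; beyond the scatter), lies beyond the scatter. Compound 3 `CC[C@H]1CN(c2nc(N)c(C(=O)NCCNS(N)(=O)=O)nc2Cl)CCN1C1CCN(Cc2ccc(F)c(F)c2)CC1` differs from compound 2 by 3,4-difluorophenyl in place of 4-chlorophenyl on a saturated chain carbon bound to an amine nitrogen in a ring. Among the measured compounds shown here, no measured step touches this part of the structure; the one known step concerns the amide side chain instead. The expectation for compound 3 therefore rests on compound 2 alone, with a step of a 1.6-fold higher number from compound 2 to compound 3 (0.20 log units; within the scatter) that is expected to stay within the scatter. Compound 3 is estimated at 3 nM, with a range from 1 nM to 10 nM.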

Compound 3, half-maximal inhibitory concentration: 9 nM
The estimate for compound 3 lay 3.0-fold (0.48 log units) below the measured number; the measured number falls inside the stated range.
By their numbers in this assay, from the lowest: compound 2; then compounds 1 and 3 (each within the scatter of the next).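

The group on the ring amine nitrogen is not a silent part of these molecules: in this assay, replacing 4-chlorobenzyl with 3,4-difluorobenzyl gives a 4.7-fold higher number from compound 2 to compound 3 (0.68 log units; beyond the scatter) and so weakens inhibition. Among these compounds, this is the first measured change at this place, and it shows that the halogens on this phenyl ring affect the result. No available evidence explains the loss.

On these data alone, it remains open whether the step comes from replacing the chlorine or from adding a second halogen. A 4-fluorophenyl or 3,4-dichlorophenyl group at this place would help separate these two changes.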